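A few compounds are considered here, and "the series" means these few. Any claim that something is new, unique, unknown or untested is made for them only; others in the source may bear on it.

Compound 3, `COc1ccccc1CNc1nc(N)c2nc(-c3cccs3)sc2n1`, gives 275 nM in an assay on CHO cells for displacement of a labelled ligand from adenosine receptor A3 (Homo sapiens), read by scintillation counting, with a stated time of 120 min; on this read-out lower numbers stand for stronger inhibition and higher numbers for weaker inhibition. Among the three compounds with a number, it stands second highest: compound 2, `COc1cccc(CNc2nc(N)c3nc(-c4cccs4)sc3n2)c1`, gives 430 nM and lies nearest, while compound 1, `Cc1ccc(-c2nc3c(N)nc(NCc4cccs4)nc3s2)o1`, gives 15.3 nM and lies furthest away, beyond the scatter.

Compound 4, `Nc1nc(NCc2cccs2)nc2sc(-c3cccs3)nc12`, has not been measured. It differs from compound 3 in one place: thiophen-2-yl in place of 2-methoxyphenyl on a saturated chain carbon bound to a nitrogen on an aromatic ring.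

Within the data shown here, only one measured step is recorded, a 1.6-fold lower number from compound 2 to compound 3 (0.19 log units; within the scatter), and it concerns where the methoxy group sits on the phenyl ring, not the exchange of that ring for thiophen-2-yl. It therefore says little about the change to compound 4. Among the measured compounds shown here, what does bear on it is compound 1, which carries the same thiophen-2-ylmethyl group on the ring nitrogen as compound 4 but differs from compound 3 in a second place as well, so no single step can be drawn from it; its value is the lowest of the three. Taken together, these numbers lead to the expectation of a clearly lower number for compound 4 than for compound 3, though probably not all the way down to the value of compound 1. The expected step is a 4.6-fold lower number from compound 3 to compound 4 (0.66 log units; beyond the scatter). Compound 4 is thus estimated at 60 nM, within a range from 15 nM to 250 nM.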

Compound 4, inhibition constant: 38 nM
Estimate against measurement, compound 4: 1.6-fold (0.20 log units) above; the measured number falls inside the stated range.
By their numbers in this assay, from the lowest: compound 1; then compound 4; then compounds 3 and 2 (each within the scatter of the next).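

In this assay, the exchange on a saturated chain carbon bound to a nitrogen on an aromatic ring can now be read directly: thiophen-2-yl in place of 2-methoxyphenyl gives a 7.2-fold lower number from compound 3 to compound 4 (0.86 log units; beyond the scatter), and thiophen-2-yl in place of 3-methoxyphenyl gives an 11-fold lower number from compound 2 to compound 4 (1.05 log units; beyond the scatter), whereas moving the methoxy group alone gave only a 1.6-fold lower number from compound 2 to compound 3 (0.19 log units; within the scatter). Among these compounds, the result also supplies the first single-place reading on an aromatic carbon, where thiophen-2-yl in place of 5-methylfuran-2-yl gives a 2.5-fold higher number from compound 1 to compound 4 (0.40 log units; beyond the scatter), so the number responds to the group at this second place as well. No measurement is available that accounts for either difference.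

As far as these compounds go, how a plain phenyl, a furan-2-yl or a cyclohexyl group would read on the chain carbon remains open, and with it whether the lower number follows the thiophen-2-yl ring itself or the absence of the methoxy group. On the aromatic carbon, a furan-2-yl without the methyl group or a 5-methylthiophen-2-yl would be needed to separate the contribution of the methyl group from that of the ring.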